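A few compounds are considered here, and "the series" means these few. Any claim that something is new, unique, unknown or untested is made for them only; others in the source may bear on it.

Two members of the series have been run through an assay on isolated protein for inhibition of Rho-associated protein kinase 1 (Homo sapiens), read by scintillation counting, radiometric assay and 33P incorporation, with a stated time of 40 min, in the presence of a further agent that is not named here; on this read-out higher numbers stand for weaker inhibition and lower numbers for stronger inhibition. Compound 1 `Cc1ccc(C(=O)Nc2cccc(NC(=O)COc3ccc4c(=O)ccoc4c3)c2)cc1` gives 183 nM. Among the compounds with values here, compound 2 `O=C(COc1ccc2c(=O)ccoc2c1)Nc1cccc(NC(=O)c2cnc(C(F)(F)F)s2)c1` gives 160 nM, the lowest of the two numbers so far, though the only step measured, a 1.1-fold lower number from compound 1 to compound 2 (0.06 log units; within the scatter), shows the two values within the scatter of each other and carries no word of order.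

Compound 3 `Cc1cc(C(=O)Nc2cccc(NC(=O)COc3ccc4c(=O)ccoc4c3)c2)no1` is not yet measured. It differs from compound 2 in one place: 5-methyl-1,2-oxazol-3-yl in place of 2-(trifluoromethyl)-1,3-thiazol-5-yl on a carbonyl carbon. Within the data shown here, the single measured step at this same carbonyl carbon, a 1.1-fold lower number from compound 1 to compound 2 (0.06 log units; within the scatter), swapped one aryl group for another and left the read-out unchanged beyond the scatter. On that basis no step beyond the scatter is expected in this assay for a third aryl group at the same carbon, and the estimate for compound 3 is 200 nM, with a range of 80 nM to 500 nM. The step this estimate means, a 1.3-fold higher number from compound 2 to compound 3 (0.10 log units; within the scatter), is expected to sit inside the scatter.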

Compound 3, half-maximal inhibitory concentration: 68 nM
Compound 3: the middle estimate sits 2.9-fold (0.47 log units) above what was measured; measured number outside the range, below it.
By their numbers in this assay, from the lowest: compound 3; then compounds 2 and 1 (each within the scatter of the next).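

In this assay the group on the carbonyl carbon whose other neighbours are the amide-type nitrogen now makes a difference: a 2.4-fold lower number from compound 2 to compound 3 (0.37 log units; beyond the scatter) and a 2.7-fold lower number from compound 1 to compound 3 (0.43 log units; beyond the scatter) both lie beyond the scatter, though both are modest. The earlier exchange of 4-methylphenyl for 2-(trifluoromethyl)-1,3-thiazol-5-yl at this carbon gave no such separation, so this position is not indifferent to the group it carries, and 5-methyl-1,2-oxazol-3-yl stands apart from the other two. Nothing available here explains the difference.

It remains open whether the methyl group or the ring of 5-methyl-1,2-oxazol-3-yl carries the step, since the compounds shown do not separate the two. Also open, as far as these compounds go, is how a primary amine or a carboxylic acid on this ring would read in this assay.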